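This account rests on a few compounds, and the source may have more. Where it says the series, first, only, none or still open, it means among the compounds named here.

Compound 1 `COc1cc(N(Cc2ccc(Cl)cc2)C(=O)CSC(=S)N2CCN(C(=O)OC(C)(C)C)CC2)cc(OC)c1OC` and compound 2 `COc1cc(N(Cc2ccc(Br)cc2)C(=O)CSC(=S)N2CCN(C(=O)OC(C)(C)C)CC2)cc(OC)c1OC` share one core and differ only in the halogen on the benzyl ring. In a functional assay on MGC-803 cells (Homo sapiens) for inhibition, read by CCK-8 assay, with a stated time of 48 h (on this read-out higher numbers stand for weaker inhibition and lower numbers for stronger inhibition), compound 1 gives 12900 nM and compound 2 gives 12400 nM, and the step of a 1.0-fold lower number from compound 1 to compound 2 (0.02 log units; within the scatter) shows nothing beyond the scatter. Compound 3 `COc1ccc(CN(C(=O)CSC(=S)N2CCN(C(=O)OC(C)(C)C)CC2)c2cc(OC)c(OC)c(OC)c2)cc1OC` carries a 3,4-dimethoxybenzyl group in place of the halogenated benzyl. In this assay compound 3 reaches only a limit of the assay, > 20000 nM. That is the limit of > 20000 nM in this assay, at which 1 of the 3 values shown sits. The steps of an at least 1.5-fold higher number from compound 1 to compound 3 (0.19 log units; that floor lies within the scatter) and an at least 1.6-fold higher number from compound 2 to compound 3 (0.20 log units; that floor lies within the scatter) show floors that lie within the scatter, so compound 3 stands as a limit, not a number. Compound 4 `COc1ccc(CN(C(=O)CSC(=S)N2CCN(C(=O)OC(C)(C)C)CC2)c2cc(OC)c(OC)c(OC)c2)cc1C` alters that same benzyl group: methyl in place of methoxy on an aromatic carbon. Among the compounds with values here, no measured step tests methyl in place of methoxy, so no shift beyond the scatter is expected. Compound 4 is estimated at 20000 nM, between 8000 nM and 50000 nM, a step of a number no higher from compound 3 to compound 4 (the limit leaves the size open).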

Compound 4, half-maximal inhibitory concentration: > 20000 nM
Compound 4 was reported as a limit (the forecaster's own chance of this, stated with the estimate: 50%); the middle value sits exactly at the limit.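

In this assay compound 4 is reported only as a limit, so the 4-methoxy-3-methylbenzyl group gives no number, and this is the second such result: the limit of > 20000 nM in this assay, at which 2 of the 4 values shown sit. The step between compound 3 and compound 4 cannot be read, so the change from methoxy to methyl has no measurable size here. The steps of an at least 1.6-fold higher number from compound 2 to compound 4 (0.20 log units; that floor lies within the scatter) and an at least 1.5-fold higher number from compound 1 to compound 4 (0.19 log units; that floor lies within the scatter) give only floors within the scatter, so no real gap from the halogenated compounds is established.

Still open, as far as these compounds go, is whether an amine or a carboxylic acid on this aromatic carbon would give a readable number.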